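A Pyridine Swap Carried Over to a Second Core

A few compounds are considered here, and "the series" means these few. Any claim that something is new, unique, unknown or untested is made for them only; others in the source may bear on it.

Compound 1 `CC(C)CN(NC(=O)OCc1ccccc1)C(=O)CN(Cc1ccccc1)/N=C/c1cccc(B(O)O)c1` and compound 2 `CC(C)CN(CC(=O)N(Cc1ccccc1)NC(=O)OCc1ccccc1)/N=C/c1cccc(B(O)O)c1` are built from the same atoms joined differently; the difference between the two cores is not broken down here. In a functional assay on L1210 cells (Mus musculus) for inhibition (a lower number here means a stronger inhibitor, a higher number a weaker inhibitor), compound 1 gives 16200 nM and compound 2 gives 16900 nM, two numbers within the usual scatter of each other. Compound 3 `CC(C)CN(CC(=O)N(Cc1cccnc1)NC(=O)OCc1ccccc1)/N=C/c1cccc(B(O)O)c1` carries pyridin-3-yl in place of phenyl on a saturated chain carbon bound to an amide-type nitrogen and gives 41600 nM, a step of a 2.5-fold higher number from compound 2 to compound 3 (0.39 log units; beyond the scatter). Compound 4 `CC(C)CN(NC(=O)OCc1ccccc1)C(=O)CN(Cc1cccnc1)/N=C/c1cccc(B(O)O)c1` carries pyridin-3-yl in place of phenyl on a saturated chain carbon bound to an amine nitrogen, the same kind of change, though here the place is a saturated chain carbon bound to an amine nitrogen rather than one bound to an amide-type nitrogen. Going by the values given here, the step expected here, a 2.2-fold higher number from compound 1 to compound 4 (0.35 log units; beyond the scatter), rests on the single measured step of a 2.5-fold higher number from compound 2 to compound 3 (0.39 log units; beyond the scatter) on the other core. Compound 4 is therefore expected to give about 36000 nM in this assay, within a range from 15000 nM to 85000 nM.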

Compound 4, half-maximal inhibitory concentration: 75000 nM
Estimate against measurement, compound 4: 2.1-fold (0.32 log units) below; measured number inside the range.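

In this assay, pyridin-3-yl in place of phenyl on the core of compound 1 gives a step of a 4.6-fold higher number from compound 1 to compound 4 (0.67 log units; beyond the scatter). The change moves the number the same way on both cores, and the two steps cannot be told apart: the same change on two cores in this assay, a 2.5-fold higher number (0.39 log units; beyond the scatter) from compound 2 to compound 3 and a 4.6-fold higher number (0.67 log units; beyond the scatter) from compound 1 to compound 4, 1.9-fold (0.27 log units) apart, within the scatter of two such steps. This shows that the direction and, within the scatter, the size of the step carried over between these two cores, but with a single pair on each core it does not show that the change would carry to any further core or place.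

From the compounds shown here alone, whether pyridin-4-yl or a methoxyphenyl group would give a similar step on either core stays open. So does whether the step would hold in any other assay.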